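Trifluoromethyl in Place of Methyl: Expecting Clearance of Compound 4

The compounds below may be only part of what the source reports. "The series", "measured", "known", "first", "only" and "open" are said of these compounds alone.

Compound 3 `Cc1ccc(Nc2c(NCCCCCC(=O)NO)c(=O)c2=O)cc1` and compound 2 `Cc1cccc(Nc2c(NCCCCCC(=O)NO)c(=O)c2=O)c1` both carry a methyl on the ring attached to the nitrogen, while compound 1 `O=C(CCCCCNc1c(NCc2ccccc2)c(=O)c1=O)NO` carries a benzyl there. In an ADME assay on cells (Hepatocyte, Homo sapiens) for pharmacokinetics, read by LC-MS, with a stated time of 90 min, tested at 1 uM (on this read-out higher numbers stand for fast clearance and lower numbers for slow clearance), compound 3 gives 7.2 uL/min, the lowest of the two numbers shown. Compound 2 gives 18 uL/min, and a 2.5-fold lower number from compound 2 to compound 3 (0.40 log units; beyond the scatter). Compound 1 gives only a limit of the assay, < 4.8 uL/min; from there an at least 3.7-fold higher number from compound 1 to compound 2 (0.57 log units; beyond the scatter) and an at least 1.5-fold higher number from compound 1 to compound 3 (0.17 log units; that floor lies within the scatter). Compound 4 `O=C(CCCCCNc1c(Nc2ccc(C(F)(F)F)cc2)c(=O)c1=O)NO` differs from compound 3 in one place: trifluoromethyl in place of methyl on an aromatic carbon. Among the compounds with values here, none of the measured steps exchanges a methyl for a trifluoromethyl, so they give no direct guide, and the largest step seen is only modest. For compound 4 a change within the scatter is expected, a step of a 1.2-fold lower number from compound 3 to compound 4 (0.08 log units; within the scatter). Compound 4 is estimated at 6 uL/min, with a range of 2.5 uL/min to 14 uL/min.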

Compound 4, intrinsic clearance in a liver preparation (reported as CLH), per the amount of preparation that the assay uses: 11 uL/min
Compound 4: middle estimate off by 1.8-fold (0.26 log units), on the low side; the range from low to high includes it.
By their numbers in this assay, from the lowest: compounds 3, 4 and 2 (each within the scatter of the next, the first and the last beyond it). At a limit, below all of these: compound 1.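

In this assay the exchange on this aromatic carbon gives a 1.5-fold higher number from compound 3 to compound 4 (0.18 log units; within the scatter), so a group of four heavy atoms in place of one leaves the read-out within the scatter. The earlier compounds shown here showed only that moving the methyl counts, with a 2.5-fold lower number from compound 2 to compound 3 (0.40 log units; beyond the scatter), and not that the group at this position could be enlarged without a step beyond the scatter. Nothing shown gives a cause for the new step.

From the compounds shown here alone, whether an amine or a carboxylic acid at this position would behave likewise stays open. So does the effect of trifluoromethyl where compound 2 carries its methyl.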